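This account rests on a few compounds, and the source may have more. Where it says the series, first, only, none or still open, it means among the compounds named here.

Measured in a functional assay on KB cells (Homo sapiens) for inhibition, read by MTT assay, with a stated time of 24 h, tested at 100 ug/mL; a lower number here means less inhibition of growth, a higher number more inhibition of growth at the concentration tested:
Compound 1 `O=C(CCCCC(S)CCS)Nc1ccccc1`: 15.8%
Compound 2 `O=C(CCCCC(S)CCS)Nc1ccc(F)cc1`: 28.2%
Compound 3 `COc1ccc(NC(=O)CCCCC(S)CCS)cc1`: 22.2%

Compound 3 stands within the scatter of both other compounds, as shown by a number 6.4 percentage points higher from compound 1 to compound 3 (within the scatter) and a number 6 percentage points lower from compound 2 to compound 3 (within the scatter). Compound 4 `O=C(CCCCC(S)CCS)Nc1ccc([N+](=O)[O-])cc1` has nitro in place of methoxy on an aromatic carbon, para to a large group: nitro in place of methoxy on an aromatic carbon. Among the compounds with values here, no measured compound carries nitro, so the nearest guide is the set of other changes on the aromatic carbon. The largest of these is a number 12.4 percentage points higher from compound 1 to compound 2 (beyond the scatter), a modest step, and the two steps to compound 3 stay within the scatter. The expected result is a number 3.8 percentage points higher from compound 3 to compound 4 (within the scatter), with no change beyond the scatter and no firm direction. For compound 4 the estimated value is 26%, with an expected range from 12% to 42%.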

Compound 4, percent growth inhibition at one concentration: 41.1%
Compound 4: middle estimate off by 15.1 percentage points, on the low side; the measured number falls inside the stated range.
By their numbers in this assay, from the lowest: compounds 1, 3 and 2 (each within the scatter of the next, the first and the last beyond it); then compound 4.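

In this assay the aromatic carbon para to a large group now shows a change that sets one compound apart from all the others (a number 18.9 percentage points higher from compound 3 to compound 4 (beyond the scatter); a number 12.9 percentage points higher from compound 2 to compound 4 (beyond the scatter); a number 25.3 percentage points higher from compound 1 to compound 4 (beyond the scatter)). Among the earlier changes on this carbon, only fluoro in place of hydrogen had cleared the scatter, whereas nitro gives compound 4 the highest number of the four. Nothing available here explains this gain. As far as these compounds go, whether an amine or a carboxylic acid on this carbon would give a number near that of compound 4 stays open. So does the effect of nitro with a longer chain.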